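Amide side chain: isopropyl to 2-hydroxyethyl

The source may report more compounds than this note shows. Statements on the series, on what has been measured and on what is new or still open speak of the compounds shown alone.

In a physicochemical assay for solubility (on this read-out lower numbers stand for lower solubility and higher numbers for higher solubility), compound 1 (`CNC(=O)c1cc(C(=O)NC2CCOCC2)cn(Cc2ccccc2)c1=O`) gives >= 174 ug/mL, which is a limit of the assay. Compound 2 (`CNC(=O)c1cc(C(=O)NC(C)C)cn(Cc2ccccc2)c1=O`) gives >= 136 ug/mL, which is also a limit, so it has no exact position on the scale. Within the data shown here, the one measured step, a step that the two limits leave unreadable from compound 1 to compound 2, replaces oxan-4-yl with isopropyl on an amide-type nitrogen and offers no size to carry forward.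

Compound 3 (`CNC(=O)c1cc(C(=O)NCCO)cn(Cc2ccccc2)c1=O`) has 2-hydroxyethyl in place of isopropyl at that same nitrogen: 2-hydroxyethyl in place of isopropyl on an amide-type nitrogen. Among the measured compounds shown here, no measured step covers this exchange. With no readable size as precedent, no step beyond the scatter is expected, and another limit is the likeliest report. The estimated step is a step that the limit leaves unreadable from compound 2 to compound 3. In this assay, the expected value for compound 3 is 150 ug/mL, with an estimated range of 100 ug/mL to 250 ug/mL.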

Compound 3, solubility: >= 140 ug/mL
Compound 3 gave a limit, no number; the forecaster's own chance of this, stated with the estimate: 75%; the middle value lies beyond the limit too.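

In this assay compound 3 gives >= 140 ug/mL, which is a limit. Among these compounds, compound 1, compound 2 and compound 3 all stand as limits, so no step among them can be read. Open, from the compounds shown here alone, is whether oxan-4-yl, isopropyl and 2-hydroxyethyl on the amide-type nitrogen differ at all on this read-out.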